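The source may hold more compounds than are shown below. What is called first, only, known or untested is meant among the compounds shown, and "the series" means these compounds.

Working notes on the series. In a functional assay on DU-145 cells (Homo sapiens) for inhibition (on this read-out lower numbers stand for stronger inhibition and higher numbers for weaker inhibition), compound 1 `Oc1cccc(-c2cc(-c3cccc(F)c3)cc(-c3ccccc3O)n2)c1` returns only a limit, > 50000 nM (the limit of > 50000 nM in this assay, at which 1 of the 3 values shown sits). Among the measured compounds shown here, compound 2 `Oc1cccc(-c2cc(-c3cccc(F)c3)cc(-c3cccc(O)c3)n2)c1` gives 23800 nM in this assay, and the one measured step, an at least 2.1-fold lower number from compound 1 to compound 2 (0.32 log units; beyond the scatter), is the only change in this set with a number behind it. Compound 3 `Oc1ccc(-c2cc(-c3ccccc3F)cc(-c3cccc(O)c3)n2)cc1` gives 3160 nM in this assay, the lowest of the two numbers shown, with compound 2 as its nearest neighbour. Compound 4 `Oc1ccc(-c2cc(-c3cccc(F)c3)cc(-c3cccc(O)c3)n2)cc1` differs from compound 3 by 3-fluorophenyl in place of 2-fluorophenyl on an aromatic carbon. For the measured compounds named here, no measured step bears on moving the fluorine, so the expectation for compound 4 in this assay rests on compound 3 alone and is an estimated step of a 1.0-fold higher number from compound 3 to compound 4 (0.01 log units; within the scatter), none beyond the scatter. Compound 4 is therefore expected near 3200 nM, within 1000 nM to 10000 nM.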

Compound 4, half-maximal inhibitory concentration: 2700 nM
The estimate for compound 4 lay 1.2-fold (0.07 log units) above the measured number; low and high end bracket the measured number.
By their numbers in this assay, from the lowest: compounds 4 and 3 (each within the scatter of the next); then compound 2. At a limit, above all of these: compound 1.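

With the fluorine moved, the step is a 1.2-fold lower number from compound 3 to compound 4 (0.07 log units; within the scatter), so 2-fluorophenyl and 3-fluorophenyl are not told apart here. With 3-fluorophenyl held constant, the hydroxyl position now reads as a full set, an 8.8-fold lower number from compound 2 to compound 4 (0.95 log units; beyond the scatter) and an at least 18-fold lower number from compound 1 to compound 4 (1.26 log units; beyond the scatter), with 4-hydroxyphenyl giving the lowest number of the three. Compound 1 gives only a limit: the limit of > 50000 nM in this assay, at which 1 of the 4 values shown sits.

On these data alone, whether an amine or a carboxylic acid could replace the hydroxyl of the 4-hydroxyphenyl group stays open. So does whether the fluorine position matters with other hydroxyphenyl arrangements.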